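A few compounds are considered here, and "the series" means these few. Any claim that something is new, unique, unknown or untested is made for them only; others in the source may bear on it.

Measured so far:
compound 1, `COc1ccc(Oc2ccc(N3CC(=O)N([C@@H](CC4CCN(C(=O)C(C)C)CC4)c4nc5ccc(C)cc5n4C)C3=O)cc2)cc1`: 2.4%
compound 2, `CC(C)C(=O)N1CCC(C[C@@H](c2nc3ccc(F)cc3n2C)N2C(=O)CN(c3ccc(Oc4ccc(F)cc4)cc3)C2=O)CC1`: 26.4%

Both were run in an ADME assay on microsomes from liver (Mus musculus) for metabolic stability, read by LC-MS, with a stated time of 30 min, tested at 1 ug/mL; a higher number here means that more of the compound is left, a lower number that less of the compound is left. Compound 2 holds the higher of the two numbers; compound 1 sits lower by a margin beyond the scatter, but the two structures differ in more than one place, so the gap cannot be tied to a single change. Compound 3, `Cc1ccc2nc([C@H](CC3CCN(C(=O)C(C)C)CC3)N3C(=O)CN(c4ccc(Oc5ccc(F)cc5)cc4)C3=O)n(C)c2c1`, is not yet measured. It differs from compound 2 in one place: methyl in place of fluoro on an aromatic carbon. Within the data shown here, no single-change step among the measured pair is available to calibrate this. The expectation leans downward because compound 1, which also carries the 1,6-dimethyl-1H-benzimidazol-2-yl group, gives 2.4%, although its second difference from compound 2 leaves that weight uncertain. The step of a number 12.4 percentage points lower from compound 2 to compound 3 (beyond the scatter) is expected to be a moderate decrease. Compound 3 is expected to give 14%, within 3% to 30%.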

Compound 3, percent of the compound remaining: 10.6%
For compound 3 the middle estimate is 3.4 percentage points above the measured one; the range from low to high includes it.
By their numbers in this assay, from the lowest: compounds 1 and 3 (each within the scatter of the next); then compound 2.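

In this assay, among these compounds, the 6-fluoro-1-methyl-1H-benzimidazol-2-yl to 1,6-dimethyl-1H-benzimidazol-2-yl change gives the first single-change reading at this aromatic carbon: a number 15.8 percentage points lower from compound 2 to compound 3 (beyond the scatter). The second single change, fluoro in place of methoxy on an aromatic carbon, gives a number 8.2 percentage points higher from compound 1 to compound 3 (within the scatter), so with the 1,6-dimethyl-1H-benzimidazol-2-yl group present, this step cannot be separated from the usual scatter. Of the two single changes, only methyl in place of fluoro therefore gives a step beyond the scatter.

Nothing available bears on the reason for either step. From the compounds shown here alone, it remains open whether a chloro or nitrile group at this aromatic carbon would read closer to compound 2 or compound 3, and whether the methoxy to fluoro step would stay within the scatter with the 6-fluoro-1-methyl-1H-benzimidazol-2-yl group in place.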